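The compounds below may be only part of what the source reports. "The series", "measured", "known", "first", "only" and "open" are said of these compounds alone.

Working notes on the series. Compound 1 `O[C@@H]1[C@H](O)CS[C@H]1Cn1cnc2c(NCc3cccc(Br)c3)nc(Cl)nc21` stands highest of the three numbers in an assay on CHO cells for displacement of a labelled ligand from adenosine receptor A1 (Homo sapiens), with a stated time of 60 min, tested at 10 uM (on this read-out lower numbers stand for less inhibition and higher numbers for more inhibition at the one concentration tested (going by the name of the read-out)), giving 23.6%. Compound 2 `O[C@@H]1[C@H](O)CS[C@H]1Cn1cnc2c(NCc3cccc(Br)c3)ncnc21`, which carries hydrogen in place of chloro on an aromatic carbon, gives 6.6% in this assay, a step of a number 17 percentage points lower from compound 1 to compound 2 (beyond the scatter). Compound 3 `O[C@@H]1[C@H](O)CS[C@H]1Cn1cnc2c(NCc3cccc(I)c3)ncnc21`, with iodo in place of bromo on an aromatic carbon, gives 9.6% in this assay, a step of a number 3 percentage points higher from compound 2 to compound 3 (within the scatter).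

Compound 4 `O[C@@H]1[C@H](O)CS[C@H]1Cn1cnc2c(NCc3cccc(F)c3)nc(Cl)nc21` keeps the chloro of compound 1 and differs from it by fluoro in place of bromo on an aromatic carbon. Going by the values given here, the one measured step that bears on it is the halogen exchange on the benzyl ring from compound 2 to compound 3, which stayed within the scatter; no measured step covers bromo to fluoro. In this assay compound 4 is therefore expected to show no step beyond the scatter, with the change a number 4.6 percentage points lower from compound 1 to compound 4 (within the scatter) most likely small and, if anything, downward. The estimate for compound 4 is 19%, within 6% to 32%.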

Compound 4, a percentage reported as inhibition, at one concentration (the size of the read-out at that concentration, not a potency): 7.9%
Compound 4: middle estimate off by 11.1 percentage points, on the high side, and the stated range covers the measured number.
By their numbers in this assay, from the lowest: compounds 2, 4 and 3 (each within the scatter of the next); then compound 1.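

With the chloro kept, the halogen on the benzyl ring is not a neutral choice in this assay: fluoro in place of bromo gives a number 15.7 percentage points lower from compound 1 to compound 4 (beyond the scatter). Going by these compounds alone, the only earlier halogen exchange on this ring, iodo in place of bromo, stayed within the scatter as a number 3 percentage points higher from compound 2 to compound 3 (within the scatter), so this position can respond to its halogen in at least one setting. That earlier step differs in both the halogen entering and the group held on the core, so these two steps do not separate the two factors, and no measurement here bears on the reason for the new step.

From the compounds shown here alone, it remains open whether fluoro in place of bromo gives a similar step on the core without the chloro. Also open, going by these compounds, is how a methoxy group or an amine on this aromatic carbon would read.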